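Swapping the Methoxyphenyl for a Difluorophenyl

The source may report more compounds than this note shows. Statements on the series, on what has been measured and on what is new or still open speak of the compounds shown alone.

Of the compounds shown here, two that share one core have been measured in a functional assay on MOLT-4 cells (Homo sapiens) for inhibition, read by sulforhodamine B assay, with a stated time of 48 h; a higher number here means a weaker inhibitor of growth, a lower number a stronger inhibitor of growth. Compound 1 `COc1cc(-c2cc(/C=C/C(=O)c3ccc(N)cc3)[nH]n2)cc(OC)c1OC` gives 8510 nM. Compound 2 `COc1ccc(C(=O)/C=C/c2cc(-c3cc(OC)c(OC)c(OC)c3)n[nH]2)cc1`, which carries a methoxy group in place of the amino group on an aromatic carbon, gives 6820 nM. Going by the values given here, the only step that connects them is a 1.2-fold lower number from compound 1 to compound 2 (0.10 log units; within the scatter), so the two numbers cannot be told apart, and compound 2 merely has the lower of the two numbers rather than a meaningfully better one.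

Compound 3 `COc1cc(-c2cc(/C=C/C(=O)c3ccc(F)c(F)c3)[nH]n2)cc(OC)c1OC` has not yet been measured. It differs from compound 2 by 3,4-difluorophenyl in place of 4-methoxyphenyl on a carbonyl carbon. Among the compounds with values here, no measured step changes this part of the molecule in the same way; the one step available, from compound 1 to compound 2, also altered the group on this aromatic ring and stayed inside the scatter. On that slim basis the expectation for this assay is a step of a 1.0-fold higher number from compound 2 to compound 3 (0.01 log units; within the scatter), that is, nothing clearly beyond the scatter in either direction. Compound 3 is therefore estimated at 7000 nM, with a plausible range from 2500 nM to 20000 nM.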

Compound 3, concentration for total growth inhibition: 9090 nM
For compound 3 the middle estimate is 1.3-fold (0.11 log units) below the measured one; the measured number falls inside the stated range.
By their numbers in this assay, from the lowest: compounds 2, 1 and 3 (each within the scatter of the next).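

In this assay, 3,4-difluorophenyl on the carbonyl carbon in place of 4-methoxyphenyl gives a 1.3-fold higher number from compound 2 to compound 3 (0.12 log units; within the scatter), and in place of 4-aminophenyl it gives a 1.1-fold higher number from compound 1 to compound 3 (0.03 log units; within the scatter). Going by these compounds alone, with the earlier step, this means that three aromatic groups at this one place, carrying an amino group, a methoxy group or two fluorines, cannot be told apart in this read-out, whereas the first two compounds offered only a single comparison. Nothing available explains why the numbers stay so close together.

The compounds shown all keep a substituted phenyl ring on the carbonyl carbon, so it remains open whether a carboxylic acid on that ring, or a cyclohexyl ring or a simple methyl group in place of it, would produce a step beyond the scatter. As far as these compounds go, they also all share the same core with its three methoxy groups, so it remains open whether replacing those methoxy groups with hydroxy groups would change the number more than any swap on the carbonyl side has done.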